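A methyl group leaves compound 2

A few compounds are considered here, and "the series" means these few. Any claim that something is new, unique, unknown or untested is made for them only; others in the source may bear on it.

Compound 1 `Cc1ccccc1Nc1nc(Nc2cc(Cl)ccn2)ncc1Cl`: > 100000 nM
Compound 2 `Cc1ccccc1Nc1nc(Nc2ccc(N3CCN(C)CC3)cn2)ncc1Cl`: 5210 nM

Both compounds were tested in a functional assay on MCF7 cells (Homo sapiens) for inhibition, read by CCK-8 assay, with a stated time of 48 h; on this read-out lower numbers stand for stronger inhibition of growth and higher numbers for weaker inhibition of growth. For compound 1, the entry > 100000 nM is a limit of the assay and not a number. Among the compounds with values here, compound 2, at 5210 nM, therefore holds the only true number so far.

Compound 3 `Cc1ccccc1Nc1nc(Nc2ccc(N3CCNCC3)cn2)ncc1Cl` differs from compound 2 in one place: hydrogen in place of methyl on an amine nitrogen in a ring. Hydrogen stands in place of methyl on an amine nitrogen in a ring, so 4-methylpiperazin-1-yl becomes piperazin-1-yl.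

Within the data shown here, no measured pair shows this change, so the expectation simply starts from compound 2 at 5210 nM. The expected step of a 1.2-fold lower number from compound 2 to compound 3 (0.06 log units; within the scatter) in this assay is none beyond the scatter, with no firm direction. For compound 3 the estimate is 4500 nM, with an expected range from 1500 nM to 15000 nM.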

Compound 3, concentration for 50% growth inhibition: 3410 nM
Beside the measured number, compound 3's estimate is 1.3-fold (0.12 log units) above it, and the stated range covers the measured number.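

In this assay the step at this position reads a 1.5-fold lower number from compound 2 to compound 3 (0.18 log units; within the scatter) and so 4-methylpiperazin-1-yl and piperazin-1-yl cannot be told apart on this read-out. Within the data shown here, this is the first measured pair that differs at this amine nitrogen, and it shows that the ring nitrogen can carry either hydrogen or methyl with no change beyond the usual scatter. Nothing shown here explains why the step is this small.

Going by these compounds, whether an ethyl group, an acetyl group or a longer chain on the same nitrogen would also leave the number within the scatter remains open. Also open, on these data alone, is what a morpholin-4-yl group, or an open-chain amine, would give in place of the whole piperazin-1-yl ring.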